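Replacing 4-methylpiperazin-1-yl with dimethylamino: expected tolerance

The compounds below may be only part of what the source reports. "The series", "measured", "known", "first", "only" and "open" are said of these compounds alone.

In an ADME assay on NIH3T3 cells (Mus musculus) for cytotoxicity (a lower number here means that less compound is tolerated, a higher number that more compound is tolerated), compound 3 `CN1CCN(CC#Cc2cc3c(Nc4ccc(OCc5cccc(F)c5)c(Cl)c4)ncnc3s2)CC1` gives 6.7 uM, the second highest of the three numbers in hand. Compound 1 `CN1CCN(CC#Cc2cc3ncnc(Nc4ccc(OCc5cccc(F)c5)c(Cl)c4)c3s2)CC1` gives 4.8 uM, a number within the scatter of compound 3. Compound 2 `CCOC(=O)CN(C)CC#Cc1cc2ncnc(Nc3ccc(OCc4cccc(F)c4)c(Cl)c3)c2s1` gives 52 uM, which lies beyond the scatter of compound 3 on the higher side.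

Compound 4 `CN(C)CC#Cc1cc2c(Nc3ccc(OCc4cccc(F)c4)c(Cl)c3)ncnc2s1` keeps the core of compound 3 and differs only in the side chain: dimethylamino in place of 4-methylpiperazin-1-yl on a saturated chain carbon bound to a triple-bonded carbon. One measured step removes the same 4-methylpiperazin-1-yl from the same place: an 11-fold higher number from compound 1 to compound 2 (1.03 log units; beyond the scatter). That step is large, but ((ethoxycarbonyl)methyl)(methyl)amino enters there, not dimethylamino, and it sits on the core of compound 1 rather than that of compound 3. For the measured compounds named here, no measured step has dimethylamino entering. Going by the values given here, with an 11-fold higher number from compound 1 to compound 2 (1.03 log units; beyond the scatter) as the only guide, a smaller move in the same direction in this assay is expected, estimated as a 1.8-fold higher number from compound 3 to compound 4 (0.25 log units; within the scatter). This expected move may not clear the scatter. The estimate for compound 4 is 12 uM, with an expected range of 4.5 uM to 35 uM.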

Compound 4, half-maximal toxic concentration: 41 uM
Estimate against measurement, compound 4: 3.4-fold (0.53 log units) below; the measured number lies above the stated range.
By their numbers in this assay, from the lowest: compounds 1 and 3 (each within the scatter of the next); then compounds 4 and 2 (each within the scatter of the next).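

In this assay, the replacement of 4-methylpiperazin-1-yl on a saturated chain carbon bound to a triple-bonded carbon now gives a 6.1-fold higher number from compound 3 to compound 4 (0.79 log units; beyond the scatter), so a rise beyond the scatter is no longer tied to the core of compound 1. It also does not depend on ((ethoxycarbonyl)methyl)(methyl)amino, since dimethylamino, with no ring and no ester, gives a rise in the same direction. No measurement available here explains this rise.

From the compounds shown here alone, it remains open whether the lower tolerance of compounds 1 and 3 follows the six-membered ring or its second nitrogen; morpholin-4-yl or piperidin-1-yl on the same chain carbon would help separate the two. Going by these compounds, how dimethylamino behaves on the core of compound 1 also remains open.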